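The source may hold more compounds than are shown below. What is called first, only, known or untested is meant among the compounds shown, and "the series" means these compounds.

Of the compounds shown here, two that share one core have been measured so far. In a functional assay on MCF7 cells (Homo sapiens) for cytotoxicity, read by MTT assay, with a stated time of 48 h (a higher number here means a weaker inhibitor of growth, a lower number a stronger inhibitor of growth), compound 1 `FC(F)(F)c1nc2cc(Cl)c(Cl)cc2n1C1CCCC1` gives 21000 nM, while compound 2 `CSc1nc2cc(Cl)c(Cl)cc2n1C1CCCC1` gives 3900 nM, the lower of the two numbers. Compound 3 `C[S+]([O-])c1nc2cc(Cl)c(Cl)cc2n1C1CCCC1` differs from compound 2 in a single group: a group of 3 heavy atoms (1 carbon, 1 oxygen, 1 sulfur; no ring) in place of a group of 2 heavy atoms (1 carbon, 1 sulfur; no ring), on an aromatic carbon. The change falls on an aromatic carbon between two ring nitrogen atoms, the same carbon that differs between the two measured compounds. Among the measured compounds shown here, only one measured step therefore bears on it: a 5.4-fold lower number from compound 1 to compound 2 (0.73 log units; beyond the scatter), modest but beyond the scatter. One step is thin evidence and cannot settle the direction for a new group. Since compound 2 holds the lower number, a modest rise of similar size seems the likeliest outcome in this assay. The expected step is a 1.8-fold higher number from compound 2 to compound 3 (0.25 log units; within the scatter). The estimate for compound 3 is 7000 nM, with an expected range of 2200 nM to 22000 nM.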

Compound 3, concentration for 50% growth inhibition: 500 nM
Beside the measured number, compound 3's estimate is 14-fold (1.15 log units) above it; the whole stated range lies above it.
By their numbers in this assay, from the lowest: compound 3; then compound 2; then compound 1.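

In this assay, a group with one more oxygen on the sulfur gives a 7.8-fold lower number from compound 2 to compound 3 (0.89 log units; beyond the scatter), so the aromatic carbon between two ring nitrogen atoms responds to a small change within a sulfur-bearing group, not only to the exchange of trifluoromethyl for methylsulfanyl. Across the three groups, the full change is a 42-fold lower number from compound 1 to compound 3 (1.62 log units; beyond the scatter), which leaves compound 3 with the lowest number, and no compound shown goes against this order. No measurement here explains what lies behind the drop.

Still open, from the compounds shown here alone, is whether a second oxygen on the sulfur, as in a methylsulfonyl group, or an amine on this carbon would lower the number further or raise it again. Going by these compounds, all three compounds also carry the same cyclopentyl group, so it remains unknown whether the step would hold with a cyclohexyl group there.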